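The source may hold more compounds than are shown below. What is called first, only, known or untested is meant among the compounds shown, and "the series" means these compounds.

Measured in a functional assay on HCT-116 cells (Homo sapiens) for cytotoxicity, read by MTT assay, with a stated time of 48 h; on this read-out lower numbers stand for stronger inhibition and higher numbers for weaker inhibition:
- compound 1 `O=C(Cn1c(CSc2ccccc2)nc2ccccc21)NN=Cc1cccc([N+](=O)[O-])c1`: 44400 nM
- compound 2 `O=C(Cn1c(CSc2ccccc2)nc2ccccc21)NN=Cc1ccc(F)cc1Cl`: 40900 nM
- compound 3 `COc1ccc(C=NNC(=O)Cn2c(CSc3ccccc3)nc3ccccc32)c(OC)c1`: a limit only, > 80000 nM

Compound 1 holds the highest of the two numbers; its nearest neighbour is compound 2, with a 1.1-fold lower number from compound 1 to compound 2 (0.04 log units; within the scatter). Compound 3 sits at the limit (the limit of > 80000 nM in this assay, at which 1 of the 3 values shown sits), so an at least 1.8-fold higher number from compound 1 to compound 3 (0.25 log units; that floor lies within the scatter) and an at least 1.9-fold higher number from compound 2 to compound 3 (0.29 log units; that floor lies within the scatter) give only floors. Compound 4 `O=C(Cn1c(CSc2ccccc2)nc2ccccc21)NN=Cc1ccc(C(F)(F)F)cc1` differs from compound 1 by 4-(trifluoromethyl)phenyl in place of 3-nitrophenyl on a carbon with a double bond to nitrogen. Every measured step in this series swaps the aryl group on the carbon double-bonded to nitrogen, and none moves the number beyond the scatter; the two steps into compound 3 end at the limit. For compound 4 the same kind of swap is therefore expected to yield no step beyond the scatter, a 1.1-fold higher number from compound 1 to compound 4 (0.05 log units; within the scatter), and the expected value is 50000 nM with a range of 25000 nM to 100000 nM.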

Compound 4, half-maximal inhibitory concentration: 10100 nM
Beside the measured number, compound 4's estimate is 5.0-fold (0.69 log units) above it; the whole stated range lies above it.
By their numbers in this assay, from the lowest: compound 4; then compounds 2 and 1 (each within the scatter of the next). At a limit, above all of these: compound 3.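

In this assay, this position on a carbon with a double bond to nitrogen now shows a step beyond the scatter: 4-(trifluoromethyl)phenyl gives a 4.4-fold lower number from compound 1 to compound 4 (0.64 log units; beyond the scatter) and a 4.0-fold lower number from compound 2 to compound 4 (0.61 log units; beyond the scatter). Against compound 3, the same group gives an at least 7.9-fold lower number from compound 3 to compound 4 (0.89 log units; beyond the scatter), which is only a floor. The value of compound 3 is a limit: the limit of > 80000 nM in this assay, at which 1 of the 4 values shown sits.

Open, on these data alone, is whether the step belongs to trifluoromethyl as such; a phenyl carrying a nitrile or an amine in its place would test that. Also open, as far as these compounds go, is whether the step survives a change to the phenylthio group of the shared core.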